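The source may report more compounds than this note shows. Statements on the series, on what has been measured and on what is new or still open speak of the compounds shown alone.

Measured in a functional assay on KB cells (Homo sapiens) for cytotoxicity; a higher number here means a weaker inhibitor, a lower number a stronger inhibitor:
Compound 1 `NC(=O)c1cn(Cc2ccccc2)c2ncnc(N)c12` gives 75000 nM.
Compound 2 `NC(=S)c1cn(Cc2ccccc2)c2ncnc(N)c12` gives 32000 nM.
Compound 3 `NC(=S)c1cn(COCc2ccccc2)c2ncnc(N)c12` gives only a limit of the assay, > 100000 nM.

Compound 4 `NC(=O)c1cn(COCc2ccccc2)c2ncnc(N)c12` awaits measurement in this assay. It differs from compound 3 by a group of 3 heavy atoms (1 carbon, 1 nitrogen, 1 oxygen; no ring) in place of a group of 3 heavy atoms (1 carbon, 1 nitrogen, 1 sulfur; no ring), on an aromatic carbon. The same kind of change, (a group of 3 heavy atoms (1 carbon, 1 nitrogen, 1 oxygen; no ring) in place of a group of 3 heavy atoms (1 carbon, 1 nitrogen, 1 sulfur; no ring), on an aromatic carbon), separates compound 2 from compound 1. How the core of compound 3 differs from the core of compound 2 is not broken down here. The expectation for compound 4 rests on compound 3 sitting at the limit of > 100000 nM in this assay, at which 1 of the 3 values shown sits, and on the weakening seen as a 2.3-fold higher number from compound 2 to compound 1 (0.37 log units; beyond the scatter). Compound 4 is therefore expected to remain at the limit, an estimated step that the limit leaves unreadable from compound 3 to compound 4. The estimate for compound 4 is 180000 nM, between 90000 nM and 500000 nM.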

Compound 4, half-maximal inhibitory concentration: > 100000 nM
Compound 4: no number, only a limit; the forecaster's own chance of this, stated with the estimate: 85%; the middle value is on the limit's open side.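

Within the data shown here, compound 3 and compound 4 both stop at a limit in this assay rather than giving a number, so no step between them can be read: the limit of > 100000 nM in this assay, at which 2 of the 4 values shown sit. The compounds shown leave open whether carbamoyl weakens the core of compound 3 as it does going from compound 2 to compound 1.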